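The source may hold more compounds than are shown below. What is called first, only, known or untested is meant among the compounds shown, and "the series" means these compounds.

Of the compounds shown here, two that share one core have been measured so far. Compound 1 `COc1ccc(-c2cc(/C=C/C(=O)c3ccc(N)cc3)[nH]n2)cc1` carries a single methoxy group on its outer ring, and compound 2 `COc1cc(-c2cc(/C=C/C(=O)c3ccc(N)cc3)[nH]n2)cc(OC)c1OC` carries three. In a functional assay on NCI-H226 cells (Homo sapiens) for cytotoxicity, read by sulforhodamine B assay, with a stated time of 48 h, tested at 10 uM (a higher number here means a weaker effect of the compound at the concentration tested, a lower number a stronger effect), compound 1 gives -29%, while compound 2 gives -73%. Compound 2 therefore stands lowest of the two numbers, and its nearest neighbour, compound 1, sits higher by a gap beyond the usual scatter of repeated measurements, so compound 2 shows the stronger effect at the concentration tested.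

Compound 3 `COc1ccc(-c2cc(/C=C/C(=O)c3ccc(N)cc3)[nH]n2)cc1OC` has not yet been measured. It differs from compound 2 in one place: hydrogen in place of methoxy on an aromatic carbon. Within the data shown here, no step between two measured compounds is available that would fix the size of this change, so the expectation can rest only on the two values already seen. The step expected here, a number 23 percentage points higher from compound 2 to compound 3 (beyond the scatter), points toward a weaker effect: compound 3 carries fewer methoxy groups than compound 2 and more than compound 1, whose value -29% sits well above that of compound 2. On that basis compound 3 is expected to give about -50% in this assay, within a range from -78% to -18%.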

Compound 3, a percentage reported as activity, at one concentration (the size of the read-out at that concentration, not a potency): -13%
Beside the measured number, compound 3's estimate is 37 percentage points below it; measured number above the stated range.
By their numbers in this assay, from the lowest: compound 2; then compound 1; then compound 3.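

In this assay, removing the methoxy group from this aromatic carbon, ortho to a methoxy group and meta to a large group, greatly weakens the effect, giving a number 60 percentage points higher from compound 2 to compound 3 (beyond the scatter). The other new step runs against a simple count of methoxy groups: methoxy in place of hydrogen on an aromatic carbon gives a number 16 percentage points higher from compound 1 to compound 3 (beyond the scatter), so here an added methoxy group also goes with a weaker effect, and compound 3, with a count that lies between the other two, is the weakest of the three rather than falling between them. So the same kind of change can weaken or strengthen the effect depending on where it falls on this ring, and nothing available here explains why this happens.

From the compounds shown here alone, it remains open whether the strong effect of compound 2 requires a methoxy group at this carbon, or whether a hydroxyl group, a fluorine atom or a longer ethoxy chain there would serve as well. These three compounds also cannot show whether the same order would hold in other cell types or at other concentrations.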